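Swapping a Methyl for a Phenyl on the Shared Core

The compounds below may be only part of what the source reports. "The series", "measured", "known", "first", "only" and "open" are said of these compounds alone.

Measured compounds:
compound 1 `Cc1ccc2c(c1)C(C)(C)[C@H]1COc3ccc4c(=O)c(C)c(C)oc4c3[C@H]1N2` — > 100000 nM
compound 2 `Cc1ccc2c(c1)C(C)(C)[C@H]1COc3ccc4c(=O)c(C)coc4c3[C@H]1N2` — > 100000 nM

In a functional assay on MDA-MB-231 cells (Homo sapiens) for antiproliferative activity, read by MTT assay (on this read-out higher numbers stand for weaker inhibition and lower numbers for stronger inhibition), compound 1 gives only a limit, > 100000 nM. Compound 2, which carries hydrogen in place of methyl on an aromatic carbon, likewise gives only a limit, > 100000 nM. The step from compound 1 to compound 2 is therefore a step that the two limits leave unreadable from compound 1 to compound 2, and both values sit at the limit of > 100000 nM in this assay, at which 2 of the 2 values shown sit. Going by the values given here, compound 1 thus stands at a limit of this assay, not at a number, and the one neighbouring compound shows the same.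

Compound 3 `Cc1ccc2c(c1)C(C)(C)[C@H]1COc3ccc4c(=O)c(-c5ccccc5)c(C)oc4c3[C@H]1N2` differs from compound 1 by phenyl in place of methyl on an aromatic carbon. Among the compounds with values here, no measured step covers a phenyl entering at this place; the only measured step, from methyl to hydrogen, is unreadable. The expectation for compound 3 therefore rests on the two limits alone: compound 3 is expected to stay at or near the limit, with a step of a number no higher from compound 1 to compound 3 (the limit leaves the size open) that is not expected to be readable. Compound 3 is estimated at 100000 nM, with a range from 20000 nM to 300000 nM.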

Compound 3, half-maximal inhibitory concentration: > 100000 nM
Compound 3: no number, only a limit; the forecaster's own chance of this, stated with the estimate: 65%; the middle value sits exactly at the limit.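

In this assay compound 3 gives only a limit, > 100000 nM, so the step from compound 1 to compound 3 cannot be read, because all three compounds stand at the same limit: the limit of > 100000 nM in this assay, at which 3 of the 3 values shown sit.

The compounds shown leave open how strongly any of them inhibits the growth of these cells, and whether any change on the shared core would give a readable number.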